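Saturated Five-Membered Ring in Place of Phenyl on the Chain

The source may report more compounds than this note shows. Statements on the series, on what has been measured and on what is new or still open speak of the compounds shown alone.

Measured compounds in a functional assay on HeLa cells (Homo sapiens) for cytotoxicity, read by WST assay, with a stated time of 48 h; on this read-out higher numbers stand for weaker inhibition and lower numbers for stronger inhibition:
Compound 1, `O[C@@H](c1ccccc1)[C@H]1CO[C@H](c2ccccc2)[C@@H](C/C=C/c2ccccn2)C1`: compound 1 gives 33800 nM
Compound 2, `O[C@@H](c1ccccc1)[C@H]1CO[C@H](c2ccccc2)[C@@H](C/C=C/C2CCCCC2)C1`: compound 2 gives 6440 nM
Compound 3, `O[C@@H](c1ccccc1)[C@H]1CO[C@H](c2ccccc2)[C@@H](C/C=C/c2ccccc2)C1`: compound 3 gives 6060 nM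

Compound 3 has the lowest number of the three, but its number is separated from that of compound 2 only by a gap within the usual scatter, so the two cannot be ordered; only compound 1 stands clearly apart, as shown by a 5.6-fold lower number from compound 1 to compound 3 (0.75 log units; beyond the scatter) and a 5.2-fold lower number from compound 1 to compound 2 (0.72 log units; beyond the scatter).

Compound 4, `O[C@@H](c1ccccc1)[C@H]1CO[C@H](c2ccccc2)[C@@H](C/C=C/C2CCCC2)C1`, is not yet measured. Compared with compound 3 the change is: cyclopentyl in place of phenyl on a double-bonded chain carbon bound to a double-bonded chain carbon

The step that bears most directly on this change is a 1.1-fold lower number from compound 2 to compound 3 (0.03 log units; within the scatter), where a saturated ring and phenyl at the same place gave numbers within the scatter of each other. A cyclopentyl ring at that place is expected to behave in much the same way, so no step beyond the scatter is expected in this assay, in either direction. For compound 4 the estimated result is 7000 nM, with a range from 3000 nM to 16000 nM, which is expected to mean a step of a 1.2-fold higher number from compound 3 to compound 4 (0.06 log units; within the scatter).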

Compound 4, half-maximal inhibitory concentration: 9330 nM
Compound 4: middle estimate off by 1.3-fold (0.12 log units), on the low side, and the stated range covers the measured number.
By their numbers in this assay, from the lowest: compounds 3, 2 and 4 (each within the scatter of the next); then compound 1.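

In this assay, the five-membered non-aromatic ring of carbon only cannot be told apart from either six-membered ring at this place on the chain (a 1.5-fold higher number from compound 3 to compound 4 (0.19 log units; within the scatter)) and (a 1.4-fold higher number from compound 2 to compound 4 (0.16 log units; within the scatter)). The earlier compounds had shown this only for cyclohexyl against phenyl; among the carbon-only rings shown, neither ring size nor the loss of aromaticity now produces a readable step, although the gap to pyridin-2-yl remains beyond the scatter (a 3.6-fold lower number from compound 1 to compound 4 (0.56 log units; beyond the scatter)), so compound 1 stands alone as the exception to an otherwise flat set. Nothing available here accounts for this flatness or for the separate place of compound 1.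

The compounds shown leave open whether the same tolerance would extend to a smaller ring such as cyclopropyl, to an open chain such as tert-butyl, or to a carbon ring carrying an amine or a carboxylic acid. They also leave open whether the nitrogen of pyridin-2-yl matters through its ring position, which pyridin-3-yl or pyridin-4-yl at the same place could test.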